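A Single Inverted Stereocentre on a Saturated Chain Carbon

A few compounds are considered here, and "the series" means these few. Any claim that something is new, unique, unknown or untested is made for them only; others in the source may bear on it.

Compound 1 (`CCOC(=O)C[C@H]([C@H]1O[C@@H]2OC(C)(C)O[C@@H]2[C@H]1OCc1ccccc1)n1cnc2c(NCc3ccccc3)ncnc21`) gives 53300 nM
Compound 2 (`CCOC(=O)C[C@@H]([C@H]1O[C@@H]2OC(C)(C)O[C@@H]2[C@H]1OCc1ccccc1)n1cnc2c(NCc3ccccc3)ncnc21`) gives 57500 nM
Compound 3 (`CC1(C)O[C@H]2O[C@H]([C@H](CCO)n3cnc4c(NCc5ccccc5)ncnc43)[C@H](OCc3ccccc3)[C@H]2O1`) gives 61200 nM

In an ADME assay on Vero cells (Chlorocebus sabaeus) for cytotoxicity, read by fluorescence and resazurin assay, with a stated time of 3 days (a lower number here means that less compound is tolerated, a higher number that more compound is tolerated), compound 3 (61200 nM) lies within the scatter of compound 1 and compound 2. Compound 4 (`CC1(C)O[C@H]2O[C@H]([C@@H](CCO)n3cnc4c(NCc5ccccc5)ncnc43)[C@H](OCc3ccccc3)[C@H]2O1`) differs from compound 3 in configuration alone (the two compounds have the same atoms and bonds and differ only in configuration as drawn: 1 of 5 stereo elements differ; a stereocentre at a saturated chain carbon is drawn S in compound 3 and R in compound 4). For the measured compounds named here, the nearest precedent is a pure inversion (the fact that compounds 1 and 2 differ only in the configuration as drawn). On that showing (a 1.1-fold higher number from compound 1 to compound 2 (0.03 log units; within the scatter)) no change beyond the scatter is expected in this assay in either direction. The exchange of ethoxycarbonyl for hydroxymethyl was of like size (a 1.1-fold higher number from compound 2 to compound 3 (0.03 log units; within the scatter)). The estimate for compound 4 is 58000 nM (expected range 35000 nM to 95000 nM). This expected step (a 1.1-fold lower number from compound 3 to compound 4 (0.02 log units; within the scatter)) remains small.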

Compound 4, half-maximal cytotoxic concentration: 74900 nM
Beside the measured number, compound 4's estimate is 1.3-fold (0.11 log units) below it, within the range that was stated.
By their numbers in this assay, from the lowest: compounds 1, 2, 3 and 4 (each within the scatter of the next).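

In this assay the inversion at the saturated chain carbon now also falls within the scatter with hydroxymethyl on the chain in place of ethoxycarbonyl (a 1.2-fold higher number from compound 3 to compound 4 (0.09 log units; within the scatter)), and this step too is a pure inversion: the fact that compounds 3 and 4 differ only in the configuration as drawn. The exchange of ethoxycarbonyl for hydroxymethyl can now be read in the second configuration as well (a 1.4-fold higher number from compound 1 to compound 4 (0.15 log units; within the scatter)), and both readings lie within the scatter: the same change on two cores in this assay, a 1.1-fold higher number (0.03 log units; within the scatter) from compound 2 to compound 3 and a 1.4-fold higher number (0.15 log units; within the scatter) from compound 1 to compound 4, 1.3-fold (0.12 log units) apart, within the scatter of two such steps. As far as these compounds go, what an amine, a carboxylic acid or a longer chain in place of hydroxymethyl would give in this assay remains open, in either configuration.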